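Phenoxy in Place of Phenyl on a Longer Chain

The compounds below may be only part of what the source reports. "The series", "measured", "known", "first", "only" and "open" are said of these compounds alone.

Measured so far:
Compound 1, `CC(C)(C)OC(=O)N1CCC[C@H]1COCCCCCC/C=C/c1ccc(-c2ccccc2)cc1`, gives only a limit in a functional assay on PK9 cells (Homo sapiens) for inhibition, read by MTT assay, with a stated time of 72 h; on this read-out lower numbers stand for stronger inhibition and higher numbers for weaker inhibition: > 100000 nM.
Compound 2, `CC(C)(C)OC(=O)N1CCC[C@H]1COCCCCCCCCC/C=C/c1ccc(-c2ccccc2)cc1`, gives only a limit in this assay: > 100000 nM.
Compound 3, `CC(C)(C)OC(=O)N1CCC[C@H]1COCCCCCC/C=C/c1ccc(Oc2ccccc2)cc1`, gives 69500 nM in this assay.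

Compound 1 and compound 2 share a core that is carried on chains of different length; how the two cores differ is not broken down here. From compound 1 to compound 3 one change is made, (phenoxy in place of phenyl on an aromatic carbon), and the result is an at least 1.4-fold lower number from compound 1 to compound 3 (0.15 log units; that floor lies within the scatter). The starting point of that step is the limit of > 100000 nM in this assay, at which 2 of the 3 values shown sit, so the true size of the step is not known beyond its floor.

Compound 4, `CC(C)(C)OC(=O)N1CCC[C@H]1COCCCCCCCCC/C=C/c1ccc(Oc2ccccc2)cc1`, is not yet measured. It arises from compound 2 by the same change, (phenoxy in place of phenyl on an aromatic carbon). For the measured compounds named here, compound 2 sits at the limit of this assay, and the only measured example of this change, from compound 1 to compound 3, leaves the number close to that limit. A step of an at least 1.1-fold lower number from compound 2 to compound 4 (0.04 log units; that floor lies within the scatter) is therefore expected from compound 2 to compound 4. Compound 4 is estimated at 90000 nM, with a likely range from 40000 nM to 250000 nM.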

Compound 4, half-maximal inhibitory concentration: > 100000 nM
Compound 4 gave a limit, no number; the forecaster's own chance of this, stated with the estimate: 50%; middle value at least 1.1-fold (0.04 log units) away from the limit.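

Compound 2 and compound 4 each give only a limit in this assay, so no step can be read between them, and the change from phenyl to phenoxy has no readable size here: the limit of > 100000 nM in this assay, at which 3 of the 4 values shown sit.

The compounds shown leave open what the true values of compound 1, compound 2 and compound 4 are, and whether this change acts alike on both chain lengths.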